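This account rests on a few compounds, and the source may have more. Where it says the series, first, only, none or still open, it means among the compounds named here.

Of the compounds shown here, three sharing a core have been tested in a toxicity assay on THP-1 cells (Homo sapiens) for inhibition; on this read-out higher numbers stand for lower toxicity in this test and lower numbers for higher toxicity in this test. There, compound 1 `Cc1cccc(-c2cnc(NC(=O)c3ccc(F)cc3)n2C)c1` gives > 100000 nM, which is a limit of the assay and not a number. Compound 2 `COc1ccc(-c2cnc(NC(=O)c3cccc(C#N)c3)n2C)cc1` gives > 100000 nM, again a limit. Compound 3 `Cn1c(-c2ccccc2)cnc1NC(=O)c1ccc(Br)cc1` gives > 100000 nM, also a limit. Compound 1 therefore stands exactly where the other two stand, and no ranking among them is possible: the limit of > 100000 nM in this assay, at which 3 of the 3 values shown sit.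

Compound 4 `Cn1c(-c2cccc(F)c2)cnc1NC(=O)c1ccc(F)cc1` has not yet been measured. It differs from compound 1 in one place: fluoro in place of methyl on an aromatic carbon. In words, this is fluoro in place of methyl on an aromatic carbon, so 3-methylphenyl becomes 3-fluorophenyl. Among the compounds with values here, no two measured compounds differ in only one place, so no measured step shows how large such a change can be. For this swap, no step beyond the usual scatter is expected in this assay, and no direction is favoured. That expectation rests on compound 1, whose limit is > 100000 nM. Compound 4 is estimated at 100000 nM, with an expected range from 40000 nM to 150000 nM. This estimate means an expected a number no higher from compound 1 to compound 4 (the limit leaves the size open).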

Compound 4, half-maximal cytotoxic concentration: 58000 nM
Beside the measured number, compound 4's estimate is 1.7-fold (0.24 log units) above it; the measured number falls inside the stated range.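

In this assay compound 4 gives 58000 nM, so this is the one compound shown with an actual number. The others stay at the assay's limit: the limit of > 100000 nM in this assay, at which 3 of the 4 values shown sit.

At this position on the six-membered aromatic ring, fluoro in place of methyl comes with an at least 1.7-fold lower number from compound 1 to compound 4 (0.23 log units; that floor lies within the scatter). Compound 1 carries only a limit, so this step has a floor but no known upper size, and that floor alone does not establish a real change in toxicity.

The compounds shown leave open what other groups at this same position would do, for example an amine, a carboxylic acid or a longer chain, and whether any of them would give a number clearly lower than that of compound 4. Within the data shown here, they also leave open whether the same swap from methyl to fluoro would give a similar result with a different group on the other side of the amide, since only this one pair of compounds shows it.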